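The source may report more compounds than this note shows. Statements on the series, on what has been measured and on what is new or still open speak of the compounds shown alone.

Working notes on the series. Compound 1 `CCCCCN1C(=O)C/C(=C\c2cccc(C(=O)NCCCC)c2)C1=O` carries a pentyl on the imide nitrogen and a butylamide on the aryl ring. In an ADME assay on HCT-116 cells (Homo sapiens) for cytotoxicity, read by MTT assay, with a stated time of 72 h (a higher number here means a weaker inhibitor, a lower number a stronger inhibitor), compound 1 reaches only the assay limit, > 100000 nM, which is a limit and not a number. Compound 2 `CCOc1ccc(NC(=O)c2cccc(/C=C3\CC(=O)N(Cc4ccccc4)C3=O)c2)cc1` is the sole member with a measured number: in this assay compound 2 gives 41700 nM, and on the numbers shown it therefore stands alone. Compound 3 `CCCCNC(=O)c1cccc(/C=C2\CC(=O)N(Cc3ccccc3)C2=O)c1` has not been measured. It differs from compound 2 in one place: butyl in place of 4-ethoxyphenyl on an amide-type nitrogen. Within the data shown here, no step between two measured compounds covers this change, so the direction rests on the wider set. Compound 1 also carries the butylamide and sits at the limit (the limit of > 100000 nM in this assay, at which 1 of the 2 values shown sits). Compound 3 is thus expected to weaken, a step of a 2.2-fold higher number from compound 2 to compound 3 (0.33 log units; beyond the scatter) in this assay. The estimate for compound 3 is 90000 nM, in the range 40000 nM to 200000 nM, with a real chance that only a limit is reported.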

Compound 3, half-maximal inhibitory concentration: 95100 nM
Compound 3: the middle estimate sits 1.1-fold (0.02 log units) below what was measured; the range from low to high includes it.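

Butyl in place of 4-ethoxyphenyl on an amide-type nitrogen now has a direct measure in this assay: a 2.3-fold higher number from compound 2 to compound 3 (0.36 log units; beyond the scatter). This position therefore responds to the change, modestly, and the weaker reading goes with butyl in this pair. The second change, phenyl in place of butyl on a saturated chain carbon bound to an amide-type nitrogen in a ring, gives an at least 1.0-fold lower number from compound 1 to compound 3 (0.02 log units; that floor lies within the scatter), which establishes no gain, and compound 1 supplies only a limit for that step: the limit of > 100000 nM in this assay, at which 1 of the 3 values shown sits.

The compounds shown do not separate the contribution of the ethoxy group from that of the aromatic ring within 4-ethoxyphenyl. Going by these compounds, how an amine or a carboxylic acid on that aromatic ring, or a chain longer than butyl on the amide-type nitrogen, would read in this assay remains open.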